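The source may report more compounds than this note shows. Statements on the series, on what has been measured and on what is new or still open speak of the compounds shown alone.

In an ADME assay for permeability, using PAMPA, with a stated time of 4 h, at pH 7.4 (a lower number here means that the compound crosses the layer more slowly, a higher number that the compound crosses the layer faster), compound 1 `c1ccc2c(c1)CN[C@H](CN(CCCN1CCNCC1)[C@H]1CCCc3cccnc31)C2` gives 16 nm/s. For the measured compounds named here, this is the lower of the two numbers so far, and it lies beyond the scatter from compound 2 `c1ccc2c(c1)CN[C@@H](CN(CCCN1CCN(C3CC3)CC1)[C@H]1CCCc3cccnc31)C2`, which gives 505 nm/s. Compound 3 `c1cnc(CN(CCCN2CCNCC2)[C@H]2CCCc3cccnc32)nc1` differs from compound 1 in one place, with pyrimidin-2-yl in place of 1,2,3,4-tetrahydroisoquinolin-3-yl on a saturated chain carbon bound to an amine nitrogen. Going by the values given here, no pair of measured compounds shows this swap alone, and compound 1 and compound 2 differ in more than one place, so their gap does not give its size. Compound 1 sits at the low end of the numbers seen so far, at 16 nm/s, which leaves more room to rise than to fall. In this assay, the expected outcome is a moderate rise, estimated as a 3.8-fold higher number from compound 1 to compound 3 (0.57 log units; beyond the scatter). For compound 3, the estimated value is 60 nm/s, with an expected range of 18 nm/s to 200 nm/s.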

Compound 3, apparent permeability: 31 nm/s
Beside the measured number, compound 3's estimate is 1.9-fold (0.29 log units) above it; low and high end bracket the measured number.
By their numbers in this assay, from the lowest: compounds 1 and 3 (each within the scatter of the next); then compound 2.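

In this assay, for the compounds shown here, pyrimidin-2-yl in place of 1,2,3,4-tetrahydroisoquinolin-3-yl on a saturated chain carbon bound to an amine nitrogen gives a 1.9-fold higher number from compound 1 to compound 3 (0.29 log units; within the scatter) and so offers the first reading of this swap alone. The entering group has fewer heavy atoms, no hydrogen-bond donor and no defined stereocentre, yet compound 1 and compound 3 cannot be told apart in this measurement, so these differences together leave no effect that can be read here. Nothing measured here offers an explanation for this result.

As far as these compounds go, whether a phenyl or a dimethylamino group at this place would give a number beyond the scatter remains open. Also open, from the compounds shown here alone, is whether the same swap would read alike on compound 2, which gives 505 nm/s and carries a different group on the far end of the chain.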